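The compounds below may be only part of what the source reports. "The series", "measured", "known", "first", "only" and "open" are said of these compounds alone.

Compound 3 `CCCSc1nc(Cl)c2c(n1)N(Cc1ccccc1)C(C(=O)NCC(C)C)N2` is the only one of the three measured compounds that returns a number in a functional assay on TE-1 cells (Homo sapiens) for antiproliferative activity, read by MTT assay, with a stated time of 72 h; a higher number here means a weaker inhibitor, a lower number a stronger inhibitor: compound 3 gives 46600 nM. Compound 1 `CCCSc1nc(Cl)c2c(n1)N(Cc1ccccc1)C(C(=O)O)N2` reaches only a limit of the assay, and in this assay compound 1 shows > 64000 nM. Compound 2 `CCCSc1nc(Cl)c2c(n1)N(Cc1ccccc1)C(C(=O)NCCNC(=O)OC(C)(C)C)N2` likewise stops at a limit, and in this assay compound 2 shows > 64000 nM. Both limits sit at the same point (the limit of > 64000 nM in this assay, at which 2 of the 3 values shown sit), so the steps of an at least 1.3-fold lower number from compound 1 to compound 3 (0.13 log units; that floor lies within the scatter) and an at least 1.3-fold lower number from compound 2 to compound 3 (0.13 log units; that floor lies within the scatter) have a floor that lies within the usual scatter and no readable ceiling. Compound 4 `CCCSc1nc(Cl)c2c(n1)N(Cc1ccccc1)C(C(=O)OCC)N2` is not yet measured. It differs from compound 3 at the carbonyl carbon attached to the saturated ring carbon: ethoxy in place of isobutylamino on a carbonyl carbon. The step of an at least 1.3-fold lower number from compound 1 to compound 3 (0.13 log units; that floor lies within the scatter) touched the same carbonyl carbon, exchanging hydroxy for isobutylamino, and moved the number only by an amount the limit leaves unclear. Within the data shown here, no measured pair swaps an amide for an ester, so nothing points to a large move in either direction. The expected step of a 1.2-fold higher number from compound 3 to compound 4 (0.07 log units; within the scatter) is therefore small, with a fair chance that the assay again reports only a limit. Compound 4 is estimated at 55000 nM, within 20000 nM to 150000 nM.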

Compound 4, half-maximal inhibitory concentration: > 64000 nM
Compound 4: a limit, no number; the forecaster's own chance of this, stated with the estimate: 50%; middle value at least 1.1-fold (0.06 log units) from the limit.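

Among these compounds, no earlier pair set an ester against an amide on this carbonyl carbon, and in this assay the change to ethoxy in place of isobutylamino gives an at least 1.3-fold higher number from compound 3 to compound 4 (0.13 log units; that floor lies within the scatter). Ethoxy now joins hydroxy and (2-((tert-butoxycarbonyl)amino)ethyl)amino at one shared limit, which leaves isobutylamino as the only group shown on this carbonyl carbon that returns a number: the limit of > 64000 nM in this assay, at which 3 of the 4 values shown sit. The steps from compound 1 to compound 4 and from compound 2 to compound 4 cannot be read, and the step to the ester has only a floor within the usual scatter, so its true size stays unknown.

The compounds shown leave open how other amides at this carbonyl carbon would behave, such as a benzylamino group or a longer unbranched alkylamino chain. Also open, on these data alone, is whether any such group could move the number far from that of compound 3, which gives 46600 nM.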